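The source may hold more compounds than are shown below. What is called first, only, known or untested is meant among the compounds shown, and "the series" means these compounds.

Measured compounds in the series:
compound 1, `[O-][n+]1nc(NCc2ccccc2)[n+]([O-])c2ccccc21`: 10700 nM
compound 2, `COc1ccc(Nc2n[n+]([O-])c3ccccc3[n+]2[O-])cc1`: 12000 nM
compound 3, `CCCCCCCCNc1n[n+]([O-])c2ccccc2[n+]1[O-]`: 18200 nM

All three numbers come from a functional assay on PC-3 cells (Homo sapiens) for cytotoxicity, read by MTT assay, with a stated time of 48 h; on this read-out lower numbers stand for stronger inhibition and higher numbers for weaker inhibition. Compound 2 gives the second highest of the three numbers; its nearest neighbour is compound 1 and its furthest is compound 3, and both gaps are within the scatter, so the three compounds cannot be told apart on this read-out. Within the data shown here, the one step between compounds that differ in a single place, a 1.7-fold higher number from compound 1 to compound 3 (0.23 log units; within the scatter), also stays within the scatter; it concerns the group on the saturated chain carbon bound to the nitrogen on the aromatic ring, not a substituent on the six-membered aromatic ring of carbon only.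

Compound 4, `[O-][n+]1nc(Nc2ccccc2)[n+]([O-])c2ccccc21`, is not yet measured. Relative to compound 2 the change is hydrogen in place of methoxy on an aromatic carbon. Among the measured compounds shown here, no measured pair covers the removal of a methoxy, so no step bears on it directly; the series so far only shows that variation of the group on the amine nitrogen leaves the numbers in this assay within the scatter. On that basis the expected step of no change at the digits printed from compound 2 to compound 4 (within the scatter) is estimated as no change beyond the scatter. Compound 4 is expected to give about 12000 nM in this assay, within 5000 nM to 30000 nM.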

Compound 4, half-maximal inhibitory concentration: 17000 nM
For compound 4 the middle estimate is 1.4-fold (0.15 log units) below the measured one, and the stated range covers the measured number.
By their numbers in this assay, from the lowest: compounds 1, 2, 4 and 3 (each within the scatter of the next).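

In this assay, hydrogen in place of methoxy on an aromatic carbon, para to a large group, gives a 1.4-fold higher number from compound 2 to compound 4 (0.15 log units; within the scatter). This adds a single-place comparison on the six-membered aromatic ring of carbon only, whereas the earlier step, a 1.7-fold higher number from compound 1 to compound 3 (0.23 log units; within the scatter), concerned the group on the saturated chain carbon; at this ring position, methoxy and hydrogen cannot be told apart on this read-out, so the methoxy, with its 2 heavy atoms and 1 hydrogen-bond acceptor, is not shown to be needed for the number seen in this assay. No evidence is available that bears on this step or gives a reason for its size.

Still open, going by these compounds, is whether a group other than methoxy at this place, such as a carboxylic acid, a dimethylamino group or chlorine, would give a step beyond the scatter in this assay. Also open, on these data alone, is whether a cyclohexyl ring on the amine nitrogen, or the same hydrogen-for-methoxy exchange on the ring of the benzyl group of compound 1, would read any differently.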